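Fluoro to chloro on a shared core

The source may hold more compounds than are shown below. What is called first, only, known or untested is meant among the compounds shown, and "the series" means these compounds.

Three compounds share one core and differ in a single group: compound 1 `CCCC(Oc1ccc(-n2cc(OC)cn2)cc1)c1ccc(C(=O)NCCC(=O)O)cc1`, compound 2 `CCCC(Oc1ccc(-n2cc(C(=O)N(C)C)cn2)cc1)c1ccc(C(=O)NCCC(=O)O)cc1` and compound 3 `CCCC(Oc1ccc(-n2cc(F)cn2)cc1)c1ccc(C(=O)NCCC(=O)O)cc1`. In a physicochemical assay for lipophilicity, using the shake flask method, at pH 7.4 (a higher number here means a more lipophilic compound, a lower number a more polar compound), compound 1 gives 1.4, compound 2 gives 0.5 and compound 3 gives 2, the highest of the three.

Compound 4 `CCCC(Oc1ccc(-n2cc(Cl)cn2)cc1)c1ccc(C(=O)NCCC(=O)O)cc1` differs from compound 3 by one swap, chloro in place of fluoro on an aromatic carbon. Changes on that same carbon have already moved the number: a number 0.90 log units lower from compound 1 to compound 2 (beyond the scatter), a number 0.60 log units higher from compound 1 to compound 3 (beyond the scatter) and a number 1.50 log units higher from compound 2 to compound 3 (beyond the scatter). None of these steps has chloro entering, so they do not settle the direction, and an upward move is a judgement. This swap replaces one single-atom group with another, so a step smaller than the one shown by a number 0.60 log units higher from compound 1 to compound 3 (beyond the scatter) is expected. The expected step is a number 0.40 log units higher from compound 3 to compound 4 (beyond the scatter). Compound 4 is estimated at 2.4, with an expected range from 2.1 to 2.8.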

Compound 4, distribution coefficient: 2.6
Compound 4: middle estimate off by 0.20 log units, on the low side; the measured number falls inside the stated range.
By their numbers in this assay, from the lowest: compound 2; then compound 1; then compound 3; then compound 4.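

Chloro now stands above fluoro on this aromatic carbon in this assay: replacing one single-atom group with another gives a number 0.60 log units higher from compound 3 to compound 4 (beyond the scatter) and so matches the size of the earlier step, a number 0.60 log units higher from compound 1 to compound 3 (beyond the scatter). The two larger comparisons, a number 1.20 log units higher from compound 1 to compound 4 (beyond the scatter) and a number 2.10 log units higher from compound 2 to compound 4 (beyond the scatter), extend the range of numbers reached by changing this one carbon, with the dimethylcarbamoyl and chloro compounds at its two ends. No measurement here explains why chloro gives a higher number than fluoro.

The compounds shown leave open whether bromo, or a carbon-based group such as methyl or trifluoromethyl, would take the number higher still or bring it back down. They also leave open whether the swap from fluoro to chloro would give a step of similar size on a different core.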